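The source may hold more compounds than are shown below. What is called first, only, known or untested is meant among the compounds shown, and "the series" means these compounds.

Among the compounds with values here, compound 1 `COc1cc(N2C(N)=C(C#N)C(c3ccc(Cl)cc3Cl)C3=C2CC(C)(C)CC3=O)cc(OC)c1OC` heads the series as measured so far: in a functional assay on Ehrlich cells (Mus musculus) for cytotoxicity, tested at 25 ug/mL (on this read-out higher numbers stand for a stronger effect at the one concentration tested and lower numbers for a weaker effect), compound 1 gives 55%, the highest of the three numbers known. Compound 2 `COc1cc(N2C(N)=C(C#N)C(c3cccc([N+](=O)[O-])c3)C3=C2CC(C)(C)CC3=O)cc(OC)c1OC` gives 20% in this assay, and compound 3 `COc1cc(N2C(N)=C(C#N)C(c3ccccc3Cl)C3=C2CC(C)(C)CC3=O)cc(OC)c1OC` gives 15%. Both steps away from compound 1 are large: a number 35 percentage points lower from compound 1 to compound 2 (beyond the scatter) and a number 40 percentage points lower from compound 1 to compound 3 (beyond the scatter). Between compounds 2 and 3 the difference is small, a number 5 percentage points lower from compound 2 to compound 3 (within the scatter).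

Compound 4 `COc1cc(N2C(N)=C(C#N)C(c3cccs3)C3=C2CC(C)(C)CC3=O)cc(OC)c1OC` differs from compound 1 in one place: thiophen-2-yl in place of 2,4-dichlorophenyl on a saturated ring carbon. The step that bears on it most directly is the exchange of the same group on the same saturated ring carbon, a number 35 percentage points lower from compound 1 to compound 2 (beyond the scatter), a large drop; the loss of a single chloro from that group, a number 40 percentage points lower from compound 1 to compound 3 (beyond the scatter), gave a drop of about the same size. Within the data shown here, every change made so far to the 2,4-dichlorophenyl of compound 1 lowered the read-out in this assay beyond the scatter, and no compound in the set runs against this. A large downward step is therefore expected for compound 4 in this assay, in the order of a number 35 percentage points lower from compound 1 to compound 4 (beyond the scatter). The estimate for compound 4 is 20%, with a range from 5% to 40%, pending the measurement of the thiophen-2-yl compound itself.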

Compound 4, a percentage reported as activity, at one concentration (the size of the read-out at that concentration, not a potency): 10%
Compound 4: middle estimate off by 10 percentage points, on the high side; the measured number falls inside the stated range.
By their numbers in this assay, from the lowest: compounds 4, 3 and 2 (each within the scatter of the next); then compound 1.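

In this assay the exchange of 2,4-dichlorophenyl for thiophen-2-yl on this saturated ring carbon gives another large drop, a number 45 percentage points lower from compound 1 to compound 4 (beyond the scatter), so the loss now extends from six-membered carbon aromatic rings to a five-membered aromatic ring with one hetero atom. Within the data shown here, the thiophen-2-yl compound does not separate from the other two compounds that lack the 2,4-dichlorophenyl group, a number 5 percentage points lower from compound 3 to compound 4 (within the scatter) and a number 10 percentage points lower from compound 2 to compound 4 (within the scatter), so 2-chlorophenyl, 3-nitrophenyl and thiophen-2-yl cannot be ranked on this read-out, and among the four compounds the high number stays with 2,4-dichlorophenyl alone, with no compound going against this. Nothing available explains the drop at this position.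

Still open, on these data alone, is whether the number of compound 1 needs both chloro groups, and what a 4-chlorophenyl, a 2,4-difluorophenyl or a saturated cyclohexyl on this carbon would give. Also open, as far as these compounds go, is whether the effect of 2,4-dichlorophenyl holds when the 3,4,5-trimethoxyphenyl group on the ring nitrogen gives way to a plain phenyl or a simple alkyl chain such as butyl.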